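Dropping the nitrile from an aryloxypropyl piperidine

The source may hold more compounds than are shown below. What is called first, only, known or untested is meant among the compounds shown, and "the series" means these compounds.

Compounds measured:
compound 1, `COc1cc(C(C)=O)ccc1OCCCN1CCC(=C(c2ccc(F)cc2)c2ccc(F)cc2)CC1`: 3.98 nM
compound 2, `N#Cc1ccc(OCCCN2CCC(C(c3ccc(F)cc3)c3ccc(F)cc3)CC2)cc1`: 5.01 nM

In a functional assay (aorta) with Oryctolagus cuniculus as the target (on this read-out higher numbers stand for weaker binding and lower numbers for tighter binding), compound 2 gives 5.01 nM, and it sits alongside compound 1, the gap between the two being within the usual scatter. Compound 3, `Fc1ccc(C(c2ccc(F)cc2)C2CCN(CCCOc3ccccc3)CC2)cc1`, has not yet been measured. The change from compound 2 to compound 3 is hydrogen in place of cyano on an aromatic carbon. Among the compounds with values here, no measured pair shows this change here, so its size is unknown; a modest step toward a weaker binding, beyond the scatter, is expected, read as a 2.2-fold higher number from compound 2 to compound 3 (0.34 log units; beyond the scatter). For compound 3 the estimated value in this assay is 11 nM, expected to lie between 3.5 nM and 35 nM.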

Compound 3, dissociation constant: 1.59 nM
For compound 3 the middle estimate is 6.9-fold (0.84 log units) above the measured one; the measured number lies below the stated range.
By their numbers in this assay, from the lowest: compound 3; then compounds 1 and 2 (each within the scatter of the next).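

In this assay the cyano group proves unnecessary at this position: hydrogen in place of cyano on this aromatic carbon, para to a large group, gives a 3.2-fold lower number from compound 2 to compound 3 (0.50 log units; beyond the scatter) and so moves toward tighter binding. The 4-cyanophenoxy group can therefore be cut back to phenoxy without loss on this read-out. Nothing available here accounts for the direction of this step. From the compounds shown here alone, whether an amine or a carboxylic acid at the same place would read closer to hydrogen or to cyano remains open. So does whether the change would run the same way on the core of compound 1.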